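Swapping the amine tail on a second core

This account rests on a few compounds, and the source may have more. Where it says the series, first, only, none or still open, it means among the compounds named here.

The four compounds share one design: an amide tail carrying a small amine, attached to one of two closely related cores. Compound 1 `C=C(c1ccc(OC)cc1NC(=O)CNCC)c1ccc(OC)c2c1OC(C)(C)C=C2` and compound 3 `C=C(c1ccc(OC)cc1NC(=O)CN(C)C)c1ccc(OC)c2c1OC(C)(C)C=C2` are built on one core; compound 2 `C=C(c1ccc(OC)cc1NC(=O)CNCC)c1ccc(OC)c2c1C=CC(C)(C)O2` and compound 4 `C=C(c1ccc(OC)cc1NC(=O)CN(C)C)c1ccc(OC)c2c1C=CC(C)(C)O2` are built on the other. The difference between the two cores is not broken down here.

In a functional assay on HCT-8 cells (Homo sapiens) for antiproliferative activity, read by MTT assay, with a stated time of 48 h (a lower number here means a stronger inhibitor, a higher number a weaker inhibitor), compound 1 gives 1380 nM. Compound 3 gives 690 nM. The change between them, (dimethylamino in place of ethylamino on a saturated chain carbon bound to a carbonyl carbon), made a step of a 2.0-fold lower number from compound 1 to compound 3 (0.30 log units; within the scatter). Compound 2 gives 3050 nM, the highest of the three numbers, and lies beyond the scatter from both compound 1 and compound 3.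

Compound 4 carries the same change on the second core: dimethylamino in place of ethylamino on a saturated chain carbon bound to a carbonyl carbon. The change sits at the same place in both pairs, so it is the same change, not merely the same kind. For the measured compounds named here, its step is expected to resemble the earlier one because a 2.0-fold lower number from compound 1 to compound 3 (0.30 log units; within the scatter) is the only measured instance, so the step is estimated at a 2.0-fold lower number from compound 2 to compound 4 (0.31 log units; beyond the scatter). Compound 4 is therefore expected to give 1500 nM, between 700 nM and 3500 nM.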

Compound 4, half-maximal inhibitory concentration: 1920 nM
For compound 4 the middle estimate is 1.3-fold (0.11 log units) below the measured one, and the stated range covers the measured number.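

The replacement of ethylamino by dimethylamino on the second core gave a 1.6-fold lower number from compound 2 to compound 4 (0.20 log units; within the scatter) in this assay and this step closely matches the one on the first core, with the gap between them no larger than repeat measurements would give: the same change on two cores in this assay, a 2.0-fold lower number (0.30 log units; within the scatter) from compound 1 to compound 3 and a 1.6-fold lower number (0.20 log units; within the scatter) from compound 2 to compound 4, 1.3-fold (0.10 log units) apart, within the scatter of two such steps

So within these four compounds, the change carries from one core to the other with a similar size of step. It does not show that the change truly lowers the number, since each step on its own lies within the scatter, and two pairs say nothing about how it would behave on a further core.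

Going by these compounds, only ethylamino and dimethylamino appear at this place, so it stays open how a diethylamino group, a primary amine or a ring amine such as pyrrolidine would fare on either core. On these data alone, all the numbers also come from a single cell line, so whether the two steps stay this similar in other cells remains open.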